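A few compounds are considered here, and "the series" means these few. Any claim that something is new, unique, unknown or untested is made for them only; others in the source may bear on it.

- Compound 1 `CN1C/C(=C\c2c(F)cc(F)cc2F)C(=O)/C(=C/c2c(F)cc(F)cc2F)C1`: > 10000 nM
- Compound 2 `CCN1C/C(=C\c2cc(F)cc(F)c2)C(=O)/C(=C/c2cc(F)cc(F)c2)C1`: 550 nM

In a functional assay on HCT-116 cells (Homo sapiens) for cytotoxicity, read by MTT assay, with a stated time of 72 h (on this read-out higher numbers stand for weaker inhibition and lower numbers for stronger inhibition), compound 1 gives > 10000 nM, which is a limit of the assay and not a number. Compound 2 gives 550 nM, so a measurable number is possible among these compounds. Compound 3 `CCN1C/C(=C\c2c(F)cc(F)cc2F)C(=O)/C(=C/c2c(F)cc(F)cc2F)C1` has not yet been measured. It differs from compound 1 by one change, methyl in place of hydrogen on a saturated chain carbon bound to an amine nitrogen in a ring, which turns methyl into ethyl: methyl in place of hydrogen on a saturated chain carbon bound to an amine nitrogen in a ring. The step of an at least 2.5-fold lower number from compound 1 to compound 3 (0.39 log units; beyond the scatter) is expected to be modest and toward stronger inhibition, though it may not be large enough to leave the limit. For compound 3 the estimated value is 4000 nM, with an expected range from 800 nM to 10000 nM.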

Compound 3, half-maximal inhibitory concentration: 1100 nM
Compound 3: middle estimate off by 3.6-fold (0.56 log units), on the high side, and the stated range covers the measured number.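

In this assay the result is an at least 9.0-fold lower number from compound 1 to compound 3 (0.95 log units; beyond the scatter) and comes from methyl in place of hydrogen on a saturated chain carbon bound to an amine nitrogen in a ring, which turns methyl into ethyl. This position therefore responds to a single added carbon while the rest of compound 1 stays the same. The step gives only a minimum size, since the value for compound 1 is a limit of the assay and not a number: the limit of > 10000 nM in this assay, at which 1 of the 3 values shown sits.

As far as these compounds go, whether a propyl group or a longer chain at this place lowers the number further remains open. So does the effect of a cyclopropyl group there.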